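Working notes: from cyano to methylsulfanyl

This account rests on a few compounds, and the source may have more. Where it says the series, first, only, none or still open, it means among the compounds named here.

Measured so far in an ADME assay on L6 cells (Rattus norvegicus) for cytotoxicity, read by fluorescence and resazurin assay, with a stated time of 72 h; a lower number here means that less compound is tolerated, a higher number that more compound is tolerated:
compound 1 `Clc1ccc(-c2c[nH]cc2C(c2ccc(Cl)cc2Cl)n2ccnc2)cc1` gives 9610 nM
compound 2 `Clc1ccc(-c2c[nH]cc2C(c2ccc(Cl)cc2)n2ccnc2)cc1` gives 4830 nM
compound 3 `N#Cc1ccc(-c2c[nH]cc2C(c2ccc(Cl)cc2Cl)n2ccnc2)cc1` gives 15000 nM

Compound 3 at 15000 nM cannot be told apart from compound 1 at 9610 nM in this assay. Among the compounds with values here, its gap to compound 2 at 4830 nM is the only one among the three pairs that lies beyond the scatter.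

Next is compound 4 `CSc1ccc(-c2c[nH]cc2C(c2ccc(Cl)cc2Cl)n2ccnc2)cc1`, which differs from compound 3 by methylsulfanyl in place of cyano on an aromatic carbon, para to a large group: methylsulfanyl in place of cyano on an aromatic carbon.

Two measured steps are available. Cyano in place of chloro at this same kind of place gave a 1.6-fold higher number from compound 1 to compound 3 (0.19 log units; within the scatter) and is the closer guide. Hydrogen in place of chloro gave a 2.0-fold lower number from compound 1 to compound 2 (0.30 log units; within the scatter) but concerns a different carbon, so it bears only on how much this series moves with a single small change. Within the data shown here, no measured compound carries methylsulfanyl, so the direction is weakly supported. A small drop towards the value of compound 1 is the working expectation, with no change beyond the scatter expected: a 1.5-fold lower number from compound 3 to compound 4 (0.18 log units; within the scatter) is the estimated step. Compound 4 is estimated at 10000 nM with an expected range of 4500 nM to 22000 nM in this assay.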

Compound 4, half-maximal cytotoxic concentration: 7220 nM
Estimate against measurement, compound 4: 1.4-fold (0.14 log units) above; measured number inside the range.
By their numbers in this assay, from the lowest: compounds 2, 4, 1 and 3 (each within the scatter of the next, the first and the last beyond it).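

Within the data shown here, at the aromatic carbon para to a large group, methylsulfanyl in place of cyano gives the only single-place step in this assay that lies beyond the scatter: a 2.1-fold lower number from compound 3 to compound 4 (0.32 log units; beyond the scatter). Methylsulfanyl in place of chloro at the same carbon stays within the scatter, a 1.3-fold lower number from compound 1 to compound 4 (0.12 log units; within the scatter), and so does cyano in place of chloro, so chloro cannot be separated from either of the other two groups and only cyano and methylsulfanyl stand apart, by a modest step. No evidence on hand accounts for this step, which remains a description of the numbers alone.

Still open, going by these compounds, is whether a group of another kind at this carbon, such as an amine, a carboxylic acid or a longer chain in place of methylsulfanyl, would stay within this narrow span in this assay or leave it. Also open is whether the difference between cyano and methylsulfanyl carries over to the core of compound 2, since both groups are shown here only on the core of compound 1.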